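Dropping a Ring Methyl from the Silent Compound 2

A few compounds are considered here, and "the series" means these few. Any claim that something is new, unique, unknown or untested is made for them only; others in the source may bear on it.

Of the compounds shown here, three sharing one core have been measured in a functional assay with Alpha-1B adrenergic receptor (Homo sapiens) as the target, read by calcium flux; a lower number here means a smaller maximal response, a higher number a larger maximal response. Compound 1 `CCCn1ncnc1-c1ccccc1NCC1=NCCN1` gives 74% in this assay, and compound 3 `CCCCn1ncnc1-c1ccccc1NCC1=NCCN1` gives 83%. Within the data shown here, the step of a number 9 percentage points higher from compound 1 to compound 3 (within the scatter) is the only one-place change measured so far. Compound 2 `Cc1ccc(-c2ccccc2NCC2=NCCN2)n1C` gives 0%, the lowest of the three numbers, standing far below both compound 1 and compound 3.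

The unmeasured compound 4 `Cn1cccc1-c1ccccc1NCC1=NCCN1` differs from compound 2 in one place: hydrogen in place of methyl on an aromatic carbon. Among the measured compounds shown here, no measured step covers a methyl taken off an aromatic carbon. For the measured compounds named here, the one measured step that involves a methyl, a number 9 percentage points higher from compound 1 to compound 3 (within the scatter), concerns a saturated chain carbon and stayed within the scatter, so it offers only weak guidance here. Compound 2 sits at the floor of the scale, leaving room only for a rise or no change. Compound 4 is therefore expected to give 15% in this assay, within a range of 0% to 50%. The expected step is a number 15 percentage points higher from compound 2 to compound 4 (beyond the scatter), a modest rise at most.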

Compound 4, largest response reached (reported as maximal response), in percent of the reference or control that the assay uses: 0%
Compound 4: middle estimate off by 15 percentage points, on the high side, within the range that was stated.
By their numbers in this assay, from the lowest: compounds 2 and 4 (each within the scatter of the next); then compounds 1 and 3 (each within the scatter of the next).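

Removing the methyl from this aromatic carbon, next to the ring nitrogen and two ring bonds from the ring atom that bears a large group, gives no change at the digits printed from compound 2 to compound 4 (within the scatter) in this assay. Among these compounds, this adds something the earlier compounds could not show: the methyl at this position is not, on its own, what separates compound 2 from a measurable response. Both compounds sit at the bottom of the scale, so the step shows that this change brings no response back, but any difference hidden below that floor cannot be seen, and nothing available explains the result.

Still open, on these data alone, is whether another group on this aromatic carbon, such as methoxy or an amine, would give compound 4 a response. As far as these compounds go, it is also open whether an ethyl in place of the remaining methyl of compound 4 would do so.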